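The source may hold more compounds than are shown below. What is called first, only, known or untested is meant among the compounds shown, and "the series" means these compounds.

Measured compounds:
- compound 1, `CO[C@]1(C(=O)O)C[C@H](O)[C@@H](NC(C)=O)[C@H]([C@@H](O)[C@H](O)CNC(=O)c2ccccc2)O1`: 137000 nM
- compound 2, `CC(=O)N[C@H]1[C@H]([C@@H](O)[C@H](O)CNC(=O)c2ccc(Cl)cc2)O[C@@](OCc2ccc(F)cc2)(C(=O)O)C[C@@H]1O`: 13000 nM
- compound 3, `CC(=O)N[C@H]1[C@H]([C@@H](O)[C@H](O)CNC(=O)c2ccc(Cl)cc2)O[C@@](OCc2c(F)c(F)c(F)c(F)c2F)(C(=O)O)C[C@@H]1O`: 6100 nM

These values come from an in vitro assay on cells for binding affinity to myelin-associated glycoprotein (Mus musculus), read by surface plasmon resonance; a higher number here means weaker binding, a lower number tighter binding. Among the three, compound 3 gives the lowest number, so it binds most tightly; compound 2 is nearest, and compound 1 is furthest away. The unmeasured compound 4, `CC(=O)N[C@H]1[C@H]([C@@H](O)[C@H](O)CNC(=O)c2ccc(Cl)cc2)O[C@@](OCc2cccc(F)c2F)(C(=O)O)C[C@@H]1O`, differs from compound 3 in one place: 2,3-difluorophenyl in place of 2,3,4,5,6-pentafluorophenyl on a saturated chain carbon bound to an oxygen on a saturated carbon. Within the data shown here, the one step that bears on this change is a 2.1-fold lower number from compound 2 to compound 3 (0.33 log units; beyond the scatter), where adding fluorines to the ring lowered the number. Taking fluorines away again is therefore expected to raise the number in this assay modestly, though perhaps not all the way back to compound 2, since two fluorines remain. The estimate for compound 4 is 9000 nM, in a range from 4500 nM to 18000 nM, which means an expected step of a 1.5-fold higher number from compound 3 to compound 4 (0.17 log units; within the scatter).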

Compound 4, dissociation constant: 2400 nM
Estimate against measurement, compound 4: 3.8-fold (0.57 log units) above, outside the stated range (below it).
By their numbers in this assay, from the lowest: compound 4; then compound 3; then compound 2; then compound 1.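

In this assay, swapping 2,3,4,5,6-pentafluorophenyl for 2,3-difluorophenyl gives a 2.5-fold lower number from compound 3 to compound 4 (0.41 log units; beyond the scatter), so fewer fluorines here went with tighter binding, the opposite of what the earlier step from 4-fluorophenyl to pentafluorophenyl suggested. The 2,3-difluorophenyl group also outdoes 4-fluorophenyl, with a 5.4-fold lower number from compound 2 to compound 4 (0.73 log units; beyond the scatter), so the number of fluorines alone does not order these three compounds. Nothing available explains this result.

Still open, from the compounds shown here alone, is how a plain phenyl ring, or a ring carrying chlorine or methoxy groups instead of fluorines, would behave at this place.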